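The source may hold more compounds than are shown below. What is called first, only, known or untested is meant among the compounds shown, and "the series" means these compounds.

Compound 1 `S=C(N/N=C\c1ccc(Cl)cc1)N(Cc1ccccc1)Cc1ccccc1` gives 159000 nM in an ADME assay on Vero cells (Chlorocebus sabaeus) for cytotoxicity, read by MTT assay, with a stated time of 72 h; a lower number here means that less compound is tolerated, a higher number that more compound is tolerated.
Compound 2 `O=[N+]([O-])c1ccc(/C=N\NC(=S)N(Cc2ccccc2)Cc2ccccc2)cc1` gives < 155000 nM in this assay, a limit of the assay rather than a number.

Compound 2 thus stands at a limit in this assay, and its position relative to compound 1 is known only through the step of an at least 1.0-fold lower number from compound 1 to compound 2 (0.01 log units; that floor lies within the scatter), which does not reach beyond the scatter. Going by the values given here, the only measured step is that one, the change of nitro in place of chloro on an aromatic carbon, and it gives no indication of a shift in tolerated concentration; the limit is described by the limit of < 155000 nM in this assay, at which 1 of the 2 values shown sits.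

Compound 3 `O=[N+]([O-])c1ccc(/C=N\NC(=S)N(Cc2ccccc2)Cc2ccccc2)o1` differs from compound 2 by 5-nitrofuran-2-yl in place of 4-nitrophenyl on a carbon with a double bond to nitrogen. Among the compounds with values here, no measured step touches this exchange of a six-membered aromatic ring for a five-membered one, so the expectation rests on the single step available, which stayed within the scatter. Compound 3 is therefore expected to show no step beyond the scatter in this assay, with the estimated step that the limit leaves unreadable from compound 2 to compound 3. The estimate for compound 3 is 100000 nM, with a range from 30000 nM to 155000 nM.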

Compound 3, half-maximal cytotoxic concentration: 158000 nM
Beside the measured number, compound 3's estimate is 1.6-fold (0.20 log units) below it; measured number outside the range, above it.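

In this assay, replacing the 4-chlorophenyl group with the 5-nitrofuran-2-yl group gives a 1.0-fold lower number from compound 1 to compound 3 (0.00 log units; within the scatter), and this pair, unlike the earlier one, carries a number on both sides, so this place accepts a five-membered aromatic ring with a hetero atom without a step beyond the scatter. Measured against the nitro-bearing six-membered ring, the same exchange gives an at least 1.0-fold higher number from compound 2 to compound 3 (0.00 log units; that floor lies within the scatter), which fixes only a floor and leaves the true size of that step open. Compound 2 stands at a limit of the assay, so the comparison stays one-sided: the limit of < 155000 nM in this assay, at which 1 of the 3 values shown sits.

The compounds shown leave open whether any change at this place can move the tolerated concentration beyond the scatter, since every group tried so far is a chloro- or nitro-bearing aromatic ring. An amine or a carboxylic acid in place of the nitro group on the five-membered ring, or a change elsewhere on the shared core, remains an open question in this assay.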